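The source may hold more compounds than are shown below. What is called first, only, known or untested is meant among the compounds shown, and "the series" means these compounds.

Working notes on a small set of quinolone esters built on two related cores. Compound 1 `CCOC(=O)c1c(-c2ccc(OC)cc2)[nH]c2cccc(OC)c2c1=O` carries a 4-methoxyphenyl group; in a physicochemical assay for solubility, in phosphate buffer, at pH 7.4 (a higher number here means a more soluble compound, a lower number a less soluble compound), compound 1 gives > 100000 nM, which is a limit of the assay and not a number. Compound 2 `CCOC(=O)c1c(-c2cccc(Cl)c2)[nH]c2cccc(OC)c2c1=O` is its 3-chlorophenyl counterpart, differing by 3-chlorophenyl in place of 4-methoxyphenyl on an aromatic carbon. In this assay compound 2 gives > 100000 nM, again a limit of the assay rather than a number. From the compounds shown here alone, the step that the two limits leave unreadable from compound 1 to compound 2 therefore cannot be read, both values sitting at the limit of > 100000 nM in this assay, at which 2 of the 3 values shown sit, so the effect of this change on the first core is unknown in size and direction.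

Compound 3 `CCOC(=O)c1c(-c2ccc(OC)cc2)[nH]c2cc(OC)ccc2c1=O` has the same atoms as compound 1 joined differently; the difference between the two cores is not broken down here. In this assay, among the measured compounds shown here, compound 3 gives 8000 nM, the only plain number among the three measured compounds.

Compound 4 `CCOC(=O)c1c(-c2cccc(Cl)c2)[nH]c2cc(OC)ccc2c1=O` is still to be measured in this assay. It differs from compound 3 by 3-chlorophenyl in place of 4-methoxyphenyl on an aromatic carbon, the same change that turns compound 1 into compound 2, occurring twice among the compounds shown. Because the measured instance of this change sits at the limit of > 100000 nM in this assay, at which 2 of the 3 values shown sit, at both ends, it gives no usable size, and the expectation for compound 4 has to rest mainly on compound 3 and its value 8000 nM. The step from compound 3 to compound 4 is expected to be a 1.6-fold lower number from compound 3 to compound 4 (0.20 log units; within the scatter), small and kept near the starting point. Compound 4 is accordingly estimated at 5000 nM in this assay, with a range from 1500 nM to 20000 nM.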

Compound 4, solubility: 58000 nM
Compound 4: the middle estimate sits 12-fold (1.06 log units) below what was measured; measured number above the stated range.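

On the core of compound 3, 3-chlorophenyl in place of 4-methoxyphenyl reads in this assay as a 7.3-fold higher number from compound 3 to compound 4 (0.86 log units; beyond the scatter). The same change on the core of compound 1 cannot be read, as compound 1 and compound 2 both sit at a limit of the assay and not at a number: the limit of > 100000 nM in this assay, at which 2 of the 4 values shown sit. The series therefore offers one readable instance of this change, on one core, which shows a clear step there but not that the step carries over to the other core, in either size or direction, so no transfer between the two cores can be claimed from these compounds.

The compounds shown leave open whether the step on the core of compound 3 is particular to 3-chlorophenyl or would also appear with a different group at the same carbon, such as a phenyl ring carrying an amine. They also leave open how the two cores would respond if the ethoxycarbonyl group gave way to a carboxylic acid, and whether such a change would bring the core of compound 1 into a range where steps in this assay can be read.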